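The compounds below may be only part of what the source reports. "The series", "measured", "known", "first", "only" and "open" are said of these compounds alone.

Values in a functional assay on MOLT-4 cells (Homo sapiens) for inhibition; on this read-out lower numbers stand for stronger inhibition and higher numbers for weaker inhibition:
- Compound 1 `O=C1/C(=C/c2ccc(Cl)cc2)Cc2ccccc21`: > 500000 nM (a limit of the assay)
- Compound 2 `O=C1/C(=C/c2ccc(F)cc2)CCc2ccccc21`: 41200 nM
- Compound 3 `O=C1/C(=C/c2ccc(F)cc2)CCCc2ccccc21`: 53600 nM

Only two of these three results are numbers. Compound 1 gives > 500000 nM, which is a limit of the assay and not a number. In this assay, compound 2 gives 41200 nM and compound 3 gives 53600 nM, and these two values lie within the scatter of each other. Compound 3 therefore stands level with compound 2 on this read-out.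

Compound 4 `O=C1/C(=C/c2ccc(Br)cc2)CCCc2ccccc21` has not yet been measured. It carries bromo in place of fluoro on an aromatic carbon, para to a large group (bromo in place of fluoro on an aromatic carbon). Within the data shown here, no measured pair of compounds shows this exchange alone, so no direction is favoured and no change beyond the scatter is expected. The expectation is anchored on compound 3 at 53600 nM. The estimated 1.2-fold lower number from compound 3 to compound 4 (0.08 log units; within the scatter) stays small. The expected value for compound 4 is 45000 nM, with an estimated range of 17000 nM to 120000 nM.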

Compound 4, half-maximal inhibitory concentration: 54700 nM
Compound 4: middle estimate off by 1.2-fold (0.08 log units), on the low side; measured number inside the range.
By their numbers in this assay, from the lowest: compounds 2, 3 and 4 (each within the scatter of the next). At a limit, above all of these: compound 1.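

In this assay, among these compounds, bromo in place of fluoro on an aromatic carbon, para to a large group, is the first change in a single place that can be read, and it gives a 1.0-fold higher number from compound 3 to compound 4 (0.01 log units; within the scatter). Among the compounds shown here, on the core of compound 3, this read-out therefore does not separate fluoro from bromo at this position, which the earlier compounds could not show. For the compounds shown here, compound 1 differs from the others in more than one place and gives only a limit of the assay, so it adds no step: the limit of > 500000 nM in this assay, at which 1 of the 4 values shown sits.

The compounds shown leave open whether an amine, a methoxy group or a carboxylic acid at this position would give a number beyond the scatter. They also leave open whether the same exchange would read alike on the core of compound 2.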